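Extending the Anilino Group with an Ethyl Substituent

This account rests on a few compounds, and the source may have more. Where it says the series, first, only, none or still open, it means among the compounds named here.

Two compounds have so far been measured in an assay on isolated protein for inhibition of Nicotinamide phosphoribosyltransferase (Homo sapiens), read by WST assay, with stated times of 60 min, 5 min and 30 min, in the presence of a further agent that is not named here; on this read-out higher numbers stand for weaker inhibition and lower numbers for stronger inhibition:

- compound 1, `O=C(/C=C/c1cccnc1)NCCCc1cccc(S(=O)(=O)Nc2ccccc2)c1`, gives 235 nM
- compound 2, `O=C(/C=C/c1cccnc1)NCCCCCCc1cccc(S(=O)(=O)Nc2ccccc2)c1`, gives 10.5 nM

Compound 2 holds the lowest of the two numbers in this assay. Its nearest neighbour is compound 1, whose value stands well beyond the scatter above it, so compound 2 is the stronger inhibitor of the pair. Among the measured compounds shown here, the two differ in the length of the chain joining the amide to the sulfonamide-bearing ring, and no single-point step between them is counted here.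

Compound 3, `CCc1ccc(NS(=O)(=O)c2cccc(CCCCCCNC(=O)/C=C/c3cccnc3)c2)cc1`, has not been measured. It differs from compound 2 by ethyl in place of hydrogen on an aromatic carbon, which, read one bond further out, turns the anilino group into a (4-ethylphenyl)amino group. For the measured compounds named here, no measured pair shows what such a change does in this assay, so there is no step to lean on. The expectation for compound 3 is that the step of a 1.1-fold higher number from compound 2 to compound 3 (0.06 log units; within the scatter) stays within the usual scatter, in either direction. Compound 3 is therefore estimated at 12 nM, with a range from 3 nM to 45 nM.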

Compound 3, half-maximal inhibitory concentration: 31.5 nM
The estimate for compound 3 lay 2.6-fold (0.42 log units) below the measured number; the range from low to high includes it.
By their numbers in this assay, from the lowest: compound 2; then compound 3; then compound 1.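

Among the compounds shown here, the first reading of a change on the ring of the anilino group comes from this assay: ethyl in place of hydrogen, on an aromatic carbon para to a large group, gives a 3.0-fold higher number from compound 2 to compound 3 (0.48 log units; beyond the scatter), a modest step that lies beyond the scatter. This position therefore accepts the 4-ethylphenyl group with some loss of inhibition but not its collapse, as compound 3 still gives 31.5 nM in this assay, and of the two groups seen here, hydrogen gives the lower number. Nothing at hand accounts for the rise in the number.

Going by these compounds, whether this rise belongs to ethyl in particular or to any substituent on this carbon stays open, and a methyl group, a fluorine atom, a methoxy group or a longer propyl chain in the same place would separate the two readings. On these data alone, it is also open whether ethyl would have the same effect on the shorter chain of compound 1, and whether an amine or a carboxylic acid on this ring would move the number the other way.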